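A Bromo-to-Nitro Swap Among Compounds Read Only as Limits

The source may report more compounds than this note shows. Statements on the series, on what has been measured and on what is new or still open speak of the compounds shown alone.

Of the compounds shown here, three have been tested in a functional assay on PC-3 cells (Homo sapiens) for inhibition, read by sulforhodamine B assay, with a stated time of 48 h (a higher number here means a weaker inhibitor of growth, a lower number a stronger inhibitor of growth), and none has yielded an exact number. Compound 1 `CCOC(=O)c1nn(-c2ccc(Cl)cc2)c(-c2ccc(Br)cc2)c1CNC(C)(C)C` gives > 511000 nM; > 476000 nM (2 entries), and these entries are limits of the assay. Compound 2 `CC(C)(C)NCc1c(C(=O)O)nn(-c2ccc(Cl)cc2)c1-c1ccc(F)cc1` gives > 623000 nM, which is also a limit. Compound 3 `CC(C)(C)NCc1c(C(=O)O)nn(-c2ccc(Cl)cc2)c1-c1ccc(Br)cc1` gives > 542000 nM, again a limit, so its standing is known only in this form.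

Compound 4 `CC(C)(C)NCc1c(C(=O)O)nn(-c2ccc(Cl)cc2)c1-c1ccc([N+](=O)[O-])cc1` differs from compound 3 in one place: nitro in place of bromo on an aromatic carbon. The change turns 4-bromophenyl into 4-nitrophenyl. The closest measured change is a step that the two limits leave unreadable from compound 2 to compound 3, where fluoro gives way to bromo. That step has no readable size to carry over. With only limits to go on, no step beyond the scatter is expected in this assay, in either direction. The expected change is a step that the limit leaves unreadable from compound 3 to compound 4. For compound 4 the estimate is 570000 nM, with an expected range from 250000 nM to 800000 nM.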

Compound 4, concentration for 50% growth inhibition: > 583000 nM
Compound 4 gave a limit, no number (the forecaster's own chance of this, stated with the estimate: 85%); at least 1.0-fold (0.00 log units) between middle value and limit.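

Compound 2, compound 3 and compound 4 are all read only as limits, so the steps that lead to compound 4 cannot be read. The compounds shown leave open how fluoro, bromo and nitro compare in this assay, since none of the three has an exact value.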